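Removing a Phosphate from a Thiouracil Nucleotide

A few compounds are considered here, and "the series" means these few. Any claim that something is new, unique, unknown or untested is made for them only; others in the source may bear on it.

compound 1 `Cn1c(=O)ccn([C@@H]2O[C@H](COP(=O)(O)OP(=O)(O)OP(=O)(O)O)[C@@H](O)[C@H]2O)c1=O`: 2920 nM
compound 2 `O=c1ccn([C@@H]2O[C@H](COP(=O)(O)OP(=O)(O)O)[C@@H](O)[C@H]2O)c(=S)[nH]1`: > 1000 nM

In an in vitro functional assay on 1321-N1 cells for agonist activity at P2Y purinoceptor 4 (Homo sapiens) (a lower number here means that less compound is needed, a higher number that more compound is needed for the effect), compound 1 gives 2920 nM. For compound 2 the assay reports only a limit, > 1000 nM, not a number (the limit of > 1000 nM in this assay, at which 1 of the 2 values shown sits). Compound 3 `O=c1ccn([C@@H]2O[C@H](COP(=O)(O)O)[C@@H](O)[C@H]2O)c(=S)[nH]1` differs from compound 2 by a hydrogen atom in place of a group of 4 heavy atoms (3 oxygen, 1 phosphorus; no ring), on an oxygen. For the measured compounds named here, no measured pair here shows a step of this kind, so its size can only be guessed; the expectation is that more compound will be needed, by more than the usual scatter, although with compound 2 known only as a limit the starting point is itself uncertain. Compound 3 is expected to give 30000 nM, with a range from 3000 nM to 300000 nM. The step is expected to be a step that the limit leaves unreadable from compound 2 to compound 3.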

Compound 3, half-maximal effective concentration: > 100000 nM
Compound 3: no number, only a limit; the forecaster's own chance of this, stated with the estimate: 85%; at least 3.3-fold (0.52 log units) between middle value and limit.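

Compound 2 and compound 3 are each reported only as a limit, so the size of the step between them cannot be read. The compounds shown leave open how much replacing this phosphorus-containing group with hydrogen changes the amount of compound needed.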